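Aryl thioether swap on the shared core

A few compounds are considered here, and "the series" means these few. Any claim that something is new, unique, unknown or untested is made for them only; others in the source may bear on it.

Compound 1 `COc1ccc(Sc2nc3cc(N)cc(N)c3nc2-c2ccccc2)cc1`: in a functional assay on SK-OV-3 cells (Homo sapiens) for inhibition, read by sulforhodamine B assay, with a stated time of 48 h (on this read-out higher numbers stand for weaker inhibition of growth and lower numbers for stronger inhibition of growth), compound 1 gives < 100000 nM, which is a limit of the assay.
Compound 2 `Nc1cc(N)c2nc(-c3ccccc3)c(Sc3ccc(Cl)c(Cl)c3)nc2c1`: in this assay compound 2 gives 39800 nM.

For the measured compounds named here, compound 2 holds the only number in this assay; the other value is a limit (the limit of < 100000 nM in this assay, at which 1 of the 2 values shown sits). The step that the limit leaves unreadable from compound 1 to compound 2 therefore cannot be sized. Compound 3 `Nc1cc(N)c2nc(-c3ccccc3)c(Sc3ccc(F)cc3)nc2c1` carries 4-fluorophenyl in place of 3,4-dichlorophenyl on a sulfur. Going by the values given here, no measured step bears readably on this change, so no direction beyond the scatter is assumed, and a limit result remains possible. Compound 3 is expected at 60000 nM, within 20000 nM to 150000 nM. The expected step is a 1.5-fold higher number from compound 2 to compound 3 (0.18 log units; within the scatter).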

Compound 3, concentration for total growth inhibition: 31600 nM
Compound 3: middle estimate off by 1.9-fold (0.28 log units), on the high side; measured number inside the range.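

In this assay, the group on the sulfur now has its first readable step: 4-fluorophenyl in place of 3,4-dichlorophenyl gives a 1.3-fold lower number from compound 2 to compound 3 (0.10 log units; within the scatter). This swap therefore leaves the number within the scatter. Compound 1 gives < 100000 nM, which is a limit of the assay, and the steps from it cannot be read: the limit of < 100000 nM in this assay, at which 1 of the 3 values shown sits.

Still open, as far as these compounds go, is whether a group of another kind on the sulfur, such as a longer alkyl chain or a phenyl bearing a carboxylic acid or an amine, would move the number beyond the scatter.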